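This account rests on a few compounds, and the source may have more. Where it says the series, first, only, none or still open, it means among the compounds named here.

Compound 1 `Cc1cc(NC(=O)Nc2ccccc2C(F)(F)F)c2ccccc2n1` gives 3800 nM in a physicochemical assay for solubility, at pH 7.4; on this read-out lower numbers stand for lower solubility and higher numbers for higher solubility.
Compound 2 `Cc1cc(NC(=O)Nc2ccccc2C(N)=O)c2ccccc2n1` gives 200 nM in this assay.
Compound 3 `Cc1cc(NC(=O)Nc2ccccc2[N+](=O)[O-])c2ccccc2n1` gives 200 nM in this assay.

Compound 3 and compound 2 sit together at the lowest number of the three, since no change at the digits printed from compound 2 to compound 3 (within the scatter). Compound 1 stands apart: a 19-fold lower number from compound 1 to compound 3 (1.28 log units; beyond the scatter) and a 19-fold lower number from compound 1 to compound 2 (1.28 log units; beyond the scatter), both large.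

Compound 4 `COc1ccccc1NC(=O)Nc1cc(C)nc2ccccc12` has not been measured. Its change from compound 3 is methoxy in place of nitro on an aromatic carbon. Among the measured compounds shown here, no measured step swaps nitro for methoxy. The swap of carbamoyl for nitro changed nothing, while the swap of trifluoromethyl for either gave a large drop, so the group at this position can matter. A modest rise or no change beyond the scatter is expected, with a 3.0-fold higher number from compound 3 to compound 4 (0.48 log units; beyond the scatter) as the guess. Compound 4 is estimated at 600 nM, between 150 nM and 3000 nM.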

Compound 4, solubility: 100 nM
Estimate against measurement, compound 4: 6.0-fold (0.78 log units) above, outside the stated range (below it).
By their numbers in this assay, from the lowest: compounds 4, 2 and 3 (each within the scatter of the next); then compound 1.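

In this assay, methoxy is a third group on this aromatic carbon that falls far from trifluoromethyl (a 38-fold lower number from compound 1 to compound 4 (1.58 log units; beyond the scatter)). It also cannot be told apart from the other two groups (a 2.0-fold lower number from compound 3 to compound 4 (0.30 log units; within the scatter); a 2.0-fold lower number from compound 2 to compound 4 (0.30 log units; within the scatter)), so nitro, carbamoyl and methoxy now form one cluster, with trifluoromethyl alone standing apart. Nothing available explains that gap.

From the compounds shown here alone, whether an amine, a carboxylic acid or a longer chain such as ethoxy would join this cluster or sit nearer compound 1 remains open.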